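A few compounds are considered here, and "the series" means these few. Any claim that something is new, unique, unknown or untested is made for them only; others in the source may bear on it.

Compound 1, `Cc1ccc(Oc2cc3c(cn2)nc(COc2cccc(C(=O)O)c2)n3C)cc1`, gives 6.8 10^-6 cm/s in an ADME assay for permeability, using PAMPA, with a stated time of 4 h; a higher number here means that the compound crosses the layer faster, a lower number that the compound crosses the layer more slowly.
Compound 2, `Cn1c(COc2cccc(C(=O)O)c2)nc2ccc(Oc3ccc(Cl)cn3)cc21`, gives 16.2 10^-6 cm/s in this assay.

Of these two numbers, compound 2 stands highest; its nearest neighbour is compound 1, whose lower number lies beyond the usual scatter of this kind of measurement. Compound 3, `Cn1c(COc2cccc(C(=O)O)c2)nc2ccc(Oc3ncc(Cl)cc3Cl)cc21`, has not yet been measured. It differs from compound 2 in one place: chloro in place of hydrogen on an aromatic carbon. Among the compounds with values here, no pair of measured compounds differs in only one spot, so nothing measured here shows how such a change moves the number in this assay. Within the data shown here, the two values of compound 1 and compound 2 show only that compounds built on this shared core can differ beyond the scatter. The step is expected to be small, estimated as a 1.2-fold higher number from compound 2 to compound 3 (0.09 log units; within the scatter), and may not reach beyond the scatter. For compound 3 the expected value is 20 10^-6 cm/s, with a likely range from 10 10^-6 cm/s to 40 10^-6 cm/s.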

Compound 3, apparent permeability: 16.1 10^-6 cm/s
Compound 3: middle estimate off by 1.2-fold (0.09 log units), on the high side; measured number inside the range.
By their numbers in this assay, from the lowest: compound 1; then compounds 3 and 2 (each within the scatter of the next).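

Within the data shown here, this is the first pair that differs in one place only, so it gives the first direct reading of a single change in this assay: going from (5-chloropyridin-2-yl)oxy to (3,5-dichloropyridin-2-yl)oxy gives (a 1.0-fold lower number from compound 2 to compound 3 (0.00 log units; within the scatter)). At this aromatic carbon, ortho to a large group and two atoms from the ring nitrogen, chloro in place of hydrogen therefore gives two numbers that this measurement cannot tell apart. No measurement at hand offers an explanation for this result.

The compounds shown do not reveal whether a different group at this carbon, such as a methyl group, an amine or a carboxylic acid, would also stay within the scatter. They also leave open how chloro would behave on the other carbons of this ring.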